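Working notes: aryl exchange from compound 2 to compound 4

The compounds below may be only part of what the source reports. "The series", "measured", "known", "first", "only" and "open" are said of these compounds alone.

Within the data shown here, compound 2 `O=C(O)Cc1sc(C(c2ccc(F)cc2)c2ccc(F)cc2)nc1-c1ccnc(N2CCC2)c1` gives the highest of the three numbers so far in an in vitro assay on HEK385-7 cells for displacement of a labelled ligand from prostaglandin D2 receptor 2 (Homo sapiens) (on this read-out lower numbers stand for stronger inhibition and higher numbers for weaker inhibition), with 660 nM. Compound 1 `CCC(c1ccccc1)c1nc(-c2ccc(Cl)cc2)c(CC(=O)O)s1` gives 190 nM in this assay, and compound 3 `COc1ccc(C(c2ccccc2)c2nc(-c3ccc(Cl)cc3)c(CC(=O)O)s2)cc1` gives 8.4 nM. Among the measured compounds shown here, the one measured step, a 23-fold lower number from compound 1 to compound 3 (1.35 log units; beyond the scatter), concerns the saturated chain carbon and not the aromatic carbon changed here. Compound 4 `O=C(O)Cc1sc(C(c2ccc(F)cc2)c2ccc(F)cc2)nc1-c1ccc(Cl)cc1` differs from compound 2 by 4-chlorophenyl in place of 2-(azetidin-1-yl)pyridin-4-yl on an aromatic carbon. For the measured compounds named here, no measured step touches this position; compounds 1 and 3 both carry 4-chlorophenyl there, and their values in this assay are lower than that of compound 2. A lower number for compound 4 in this assay is therefore expected, with the step of a 4.4-fold lower number from compound 2 to compound 4 (0.64 log units; beyond the scatter) as a rough guess. Compound 4 is estimated at 150 nM, within 40 nM to 600 nM.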

Compound 4, half-maximal inhibitory concentration: 9.7 nM
For compound 4 the middle estimate is 15-fold (1.19 log units) above the measured one; measured number below the stated range.
By their numbers in this assay, from the lowest: compounds 3 and 4 (each within the scatter of the next); then compound 1; then compound 2.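

In this assay the group on this aromatic carbon proves to matter strongly: 4-chlorophenyl in place of 2-(azetidin-1-yl)pyridin-4-yl gives a 68-fold lower number from compound 2 to compound 4 (1.83 log units; beyond the scatter) with the rest of the structure unchanged. Among these compounds, this is the first measured step at this position, and it is large. Nothing available accounts for its size.

The compounds shown leave open whether the step follows the azetidine or the ring nitrogen of the pyridine. A plain pyridin-4-yl or a 4-(azetidin-1-yl)phenyl group at this carbon would separate the two.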